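The source may report more compounds than this note shows. Statements on the series, on what has been measured and on what is new or still open speak of the compounds shown alone.

Half-lives in an ADME assay on microsomes from liver (Homo sapiens) for metabolic stability, read by LC-MS, using NADPH, with a stated time of 10 min, tested at 10 uM; a higher number here means that the compound lasts longer, a lower number that the compound disappears faster:
- Compound 1 (`Nc1ncnc2c1c(Oc1cc(C(F)(F)F)ccn1)nn2C1CCCC1`) 0.333 h
- Compound 2 (`Nc1ncnc2c1c(Oc1cc(C(F)(F)F)ccn1)nn2C1CC1`) > 2.41 h (a limit, not a number)

Compound 2 stands at the limit of > 2.41 h in this assay, at which 1 of the 2 values shown sits. Compound 3 (`Nc1ncnc2c1c(Oc1cc(C(F)(F)F)ccn1)nn2[C@H]1CC[C@@H](N)CC1`) brings 4-aminocyclohexyl in place of cyclopropyl on the aromatic nitrogen: 4-aminocyclohexyl in place of cyclopropyl on an aromatic nitrogen. Going by the values given here, the only measured step at this place is an at least 7.2-fold higher number from compound 1 to compound 2 (0.85 log units; beyond the scatter), beyond the scatter, with cyclopropyl replacing cyclopentyl. Given that step, a move away from cyclopropyl is expected to lower the number by a similar or smaller size, though no measured compound carries the amine. The expected change is an at least 2.6-fold lower number from compound 2 to compound 3 (0.42 log units; beyond the scatter). For compound 3 the estimated half-life is 0.9 h, within an expected range of 0.3 h to 2.7 h.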

Compound 3, half-life: > 2.41 h
Compound 3: only a limit was reported; the forecaster's own chance of this, stated with the estimate: 15%; middle value at least 2.6-fold (0.42 log units) away from the limit.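

In this assay the change at this aromatic nitrogen gives an at least 7.2-fold higher number from compound 1 to compound 3 (0.85 log units; beyond the scatter) and so shows that the gain over cyclopentyl is not confined to cyclopropyl: it also holds for 4-aminocyclohexyl, a group that carries an amine. Compound 3 gives > 2.41 h as a limit and not a number. The step from the limit of one compound to the limit of the other cannot be read, and the two share one ceiling: the limit of > 2.41 h in this assay, at which 2 of the 3 values shown sit.

The compounds shown leave open how a plain cyclohexyl ring without the amine, or the other stereoisomer of the amine, would compare. Going by these compounds, how far the true half-lives of compound 2 and compound 3 lie beyond the limit also stays open.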